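Propargyl Sulfide Replaces Cyclohexylmethyl in a Gastric Cancer Series

The compounds below may be only part of what the source reports. "The series", "measured", "known", "first", "only" and "open" are said of these compounds alone.

Three compounds share one core and differ only in the group on the saturated chain carbon bound to a sulfur. In a functional assay on MGC-803 cells (Homo sapiens) for inhibition, read by MTT assay, with a stated time of 72 h (on this read-out higher numbers stand for weaker inhibition and lower numbers for stronger inhibition), compound 1 `Cc1cc(Nc2cc(-c3ccccc3)[nH]n2)n2nc(SCc3ccc(F)cc3)nc2n1` gives 3270 nM, compound 2 `Cc1cc(Nc2cc(-c3ccccc3)[nH]n2)n2nc(SCc3ccc(C(F)(F)F)cc3)nc2n1` gives 3520 nM, and compound 3 `Cc1cc(Nc2cc(-c3ccccc3)[nH]n2)n2nc(SCC3CCCCC3)nc2n1` gives 12600 nM, the highest of the three. The steps of a 3.9-fold higher number from compound 1 to compound 3 (0.59 log units; beyond the scatter) and a 3.6-fold higher number from compound 2 to compound 3 (0.55 log units; beyond the scatter) show the cyclohexyl group weakening inhibition, while a 1.1-fold higher number from compound 1 to compound 2 (0.03 log units; within the scatter) lies within the scatter. Compound 4 `C#CCSc1nc2nc(C)cc(Nc3cc(-c4ccccc4)[nH]n3)n2n1` carries ethynyl in place of cyclohexyl on a saturated chain carbon bound to a sulfur. Among the compounds with values here, no measured step covers an ethynyl group, so the direction is open; since the two aromatic groups gave lower numbers than cyclohexyl, a modest return toward them is expected. Compound 4 is therefore expected at 6500 nM, spanning 2000 nM to 20000 nM, a step of a 1.9-fold lower number from compound 3 to compound 4 (0.29 log units; within the scatter).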

Compound 4, half-maximal inhibitory concentration: 13400 nM
For compound 4 the middle estimate is 2.1-fold (0.31 log units) below the measured one; low and high end bracket the measured number.
By their numbers in this assay, from the lowest: compounds 1 and 2 (each within the scatter of the next); then compounds 3 and 4 (each within the scatter of the next).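

In this assay, the result shows that cyclohexyl and ethynyl on this saturated chain carbon bound to a sulfur cannot be told apart, despite their difference in size and ring content: a 1.1-fold higher number from compound 3 to compound 4 (0.03 log units; within the scatter). Compound 4 instead stands apart from both aromatic compounds, with a 3.8-fold higher number from compound 2 to compound 4 (0.58 log units; beyond the scatter) and a 4.1-fold higher number from compound 1 to compound 4 (0.61 log units; beyond the scatter). No evidence here accounts for these results. From the compounds shown here alone, what remains open is whether a plain phenyl group, a longer chain or an amine at this position would fall with compounds 1 and 2 or with compounds 3 and 4.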